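Swapping the aryl group on the triazole of a spirooxindole

The compounds below may be only part of what the source reports. "The series", "measured", "known", "first", "only" and "open" are said of these compounds alone.

Measured compounds in a functional assay on MCF7 cells (Homo sapiens) for antiproliferative activity, read by MTT assay, with a stated time of 48 h; a higher number here means a weaker inhibitor, a lower number a stronger inhibitor:
- Compound 1 `N#CC1=C(N)Oc2c(c3nc4ccccc4nc3c3ccccc23)C12C(=O)N(Cc1cnnn1-c1ccc(Br)cc1)c1ccccc12` gives 36600 nM.
- Compound 2 `COc1ccccc1-n1nncc1CN1C(=O)C2(C(C#N)=C(N)Oc3c2c2nc4ccccc4nc2c2ccccc32)c2ccccc21` gives > 50000 nM, which is a limit of the assay, not a number.
- Compound 3 `N#CC1=C(N)Oc2c(c3nc4ccccc4nc3c3ccccc23)C12C(=O)N(Cc1cnnn1-c1ccc([N+](=O)[O-])cc1)c1ccccc12` gives > 50000 nM, also a limit of the assay.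

Compound 2 therefore stands at the upper edge of what this assay reports: it is one of the two compounds sitting at the limit of > 50000 nM in this assay, at which 2 of the 3 values shown sit, and only compound 1 gives a number at all. Compound 4 `Cc1ccc(C)c(-n2nncc2CN2C(=O)C3(C(C#N)=C(N)Oc4c3c3nc5ccccc5nc3c3ccccc43)c3ccccc32)c1` keeps the shared core and differs from compound 2 only in the aryl group on the triazole nitrogen: 2,5-dimethylphenyl in place of 2-methoxyphenyl on an aromatic nitrogen.

The measured steps that bear on this are the ones that also vary that aryl group. The change from 4-bromophenyl to 2-methoxyphenyl gave an at least 1.3-fold higher number from compound 1 to compound 2 (0.13 log units; that floor lies within the scatter), and the change from bromo to nitro gave an at least 1.3-fold higher number from compound 1 to compound 3 (0.13 log units; that floor lies within the scatter); between compound 2 and compound 3 the step is a step that the two limits leave unreadable from compound 2 to compound 3. Every variation of this aryl group so far leaves the compound weak or at the limit, so no step beyond the scatter is expected, and compound 4 is expected to show a number no higher from compound 2 to compound 4 (the limit leaves the size open). Compound 4 is estimated at 50000 nM, within 20000 nM to 150000 nM.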

Compound 4, half-maximal inhibitory concentration: > 50000 nM
Compound 4 ended at the assay's limit; the forecaster's own chance of this, stated with the estimate: 60%; the middle value lies on the limit itself.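

The 2,5-dimethylphenyl group holds only carbon, whereas the 2-methoxyphenyl group it replaces has one hydrogen-bond acceptor, and in this assay compound 4 still gives > 50000 nM, which is a limit of the assay. Among these compounds, the only step with a readable floor is an at least 1.3-fold higher number from compound 1 to compound 4 (0.13 log units; that floor lies within the scatter), while the steps from the two other compounds at the limit cannot be read. An aryl group with no oxygen or nitrogen therefore joins the methoxy and nitro examples at the same ceiling: the limit of > 50000 nM in this assay, at which 3 of the 4 values shown sit.

Among the compounds shown here, how far compound 2, compound 3 and compound 4 lie beyond that limit remains unknown, and compound 1 is the only one with a number. Also open, as far as these compounds go, is whether an amine or a carboxylic acid on this aryl ring would give a measurable value in this assay.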